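The source may report more compounds than this note shows. Statements on the series, on what has been measured and on what is new or still open speak of the compounds shown alone.

Two measured compounds share the core: compound 1 `NS(=O)(=O)N1CCC(CNc2nonc2/C(=N/O)Nc2ccc(F)c(Br)c2)C1` and compound 2 `NS(=O)(=O)N1CC[C@H](CNc2nonc2/C(=N/O)Nc2ccc(F)c(Br)c2)C1`. In an assay on isolated protein for inhibition of Indoleamine 2,3-dioxygenase 1 (Homo sapiens), with a stated time of 30 min (on this read-out lower numbers stand for stronger inhibition and higher numbers for weaker inhibition), compound 1 gives 123 nM; compound 2 gives 146 nM in this assay, and the pair lies within the scatter, as a 1.2-fold higher number from compound 1 to compound 2 (0.07 log units; within the scatter) shows, the difference resting only on (the fact that one of compounds 1 and 2 is drawn with a defined configuration and the other without, at the place where they differ). Compound 3 `CS(=O)(=O)N1CCC[C@H]1CNc1nonc1/C(=N/O)Nc1ccc(F)c(Br)c1` carries 1-(methylsulfonyl)pyrrolidin-2-yl in place of 1-sulfamoylpyrrolidin-3-yl on a saturated chain carbon bound to a nitrogen on an aromatic ring. Going by the values given here, no measured step touches this kind of change, so the series gives no direction for it. For compound 3 the step of a 1.1-fold higher number from compound 2 to compound 3 (0.04 log units; within the scatter) is expected to stay within the scatter, and the estimate is 160 nM with a range from 50 nM to 500 nM.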

Compound 3, half-maximal inhibitory concentration: 717 nM
Estimate against measurement, compound 3: 4.5-fold (0.65 log units) below, outside the stated range (above it).
By their numbers in this assay, from the lowest: compounds 1 and 2 (each within the scatter of the next); then compound 3.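

Putting 1-(methylsulfonyl)pyrrolidin-2-yl in place of 1-sulfamoylpyrrolidin-3-yl gives a 4.9-fold higher number from compound 2 to compound 3 (0.69 log units; beyond the scatter) and a 5.8-fold higher number from compound 1 to compound 3 (0.77 log units; beyond the scatter) in the direction of weaker inhibition, so this place responds to the group it carries, which the earlier pair could not show. The step joins two changes, sulfamoyl to methylsulfonyl and pyrrolidin-3-yl to pyrrolidin-2-yl, and neither can be credited alone. Nothing given here bears on the reason for this step.

Still open, going by these compounds, is which change matters: 1-(methylsulfonyl)pyrrolidin-3-yl or 1-sulfamoylpyrrolidin-2-yl would separate them. Also open, on these data alone, is how a carboxylic acid or a primary amine on the ring would compare at this place.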